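Working notes: ethyl in place of methoxy

A few compounds are considered here, and "the series" means these few. Any claim that something is new, unique, unknown or untested is made for them only; others in the source may bear on it.

Measured in a functional assay on Chorioallantoic membrane (Gallus gallus, strain Leghorn), read by microscopy, with a stated time of 40 h (a lower number here means a stronger inhibitor, a higher number a weaker inhibitor), so far:
compound 1 `COc1ccc(N(C)c2ncnc3occ(C)c23)cc1` gives 80 nM
compound 2 `COc1ccc(N(c2ncnc3occ(C)c23)C(C)C)cc1` gives 480 nM
compound 3 `CCCN(c1ccc(OC)cc1)c1ncnc2occ(C)c12` gives 301 nM

Compound 1 holds the lowest number of the three, and its steps to both others lie beyond the scatter. The change to compound 4 `CCc1ccc(N(C)c2ncnc3occ(C)c23)cc1` is ethyl in place of methoxy on an aromatic carbon and puts ethyl in place of methoxy on an aromatic carbon, para to a large group. Among the compounds with values here, no measured step touches that place. The available steps alter the group on nitrogen instead: a 6.0-fold higher number from compound 1 to compound 2 (0.78 log units; beyond the scatter) and a 3.8-fold higher number from compound 1 to compound 3 (0.58 log units; beyond the scatter) are both modest and give no direction for this change. Within the data shown here, with compound 1 at 80 nM as the lowest number so far, a modest move to a higher number in this assay is expected, although a result within the scatter remains possible. The estimated change is a 2.3-fold higher number from compound 1 to compound 4 (0.35 log units; beyond the scatter) on present data. Compound 4 is expected at 180 nM with an estimated range of 50 nM to 650 nM on present data.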

Compound 4, half-maximal inhibitory concentration: 287 nM
Compound 4: middle estimate off by 1.6-fold (0.20 log units), on the low side; measured number inside the range.
By their numbers in this assay, from the lowest: compound 1; then compounds 4, 3 and 2 (each within the scatter of the next).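

Ethyl in place of methoxy on an aromatic carbon, para to a large group, gives a 3.6-fold higher number from compound 1 to compound 4 (0.55 log units; beyond the scatter), so this position is sensitive to the exchange and not only the group on nitrogen is. The exchange keeps the heavy-atom count and removes the one hydrogen-bond acceptor of methoxy. Nothing measured here explains the shift.

Open, from the compounds shown here alone, is how a hydroxyl, a chlorine or a longer alkoxy chain would read at this position. Also open, going by these compounds, is whether ethyl gives a similar step with propyl or isopropyl on the nitrogen.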